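Aryl swap at the double-bonded ring carbon: compound 3 to 4

The compounds below may be only part of what the source reports. "The series", "measured", "known", "first", "only" and "open" are said of these compounds alone.

Among the compounds with values here, in a functional assay on SK-OV-3 cells (Homo sapiens) for cytotoxicity (on this read-out higher numbers stand for weaker inhibition of growth and lower numbers for stronger inhibition of growth), compound 3 `CSc1ccc(C2=C(c3ccc(C)c(C)c3)C(=O)N3CCCC3C2)cc1` gives 300 nM, the lowest of the three numbers so far. Compound 2 `COc1ccc(C2=C(c3ccc(SC)cc3)CC3CCCN3C2=O)cc1OC(=O)C1CCCN1C(=O)OC(C)(C)C` stands at 10000 nM and compound 1 `COc1ccc(C2=C(c3ccc(SC)cc3)CC3CCCN3C2=O)cc1OC(=O)CNC(=O)OC(C)(C)C` at 20000 nM, both well above it.

Compound 4 `CSc1ccc(C2=C(c3ccc(F)cc3)C(=O)N3CCCC3C2)cc1` keeps the shared core and the 4-(methylsulfanyl)phenyl group of compound 3. It carries 4-fluorophenyl in place of 3,4-dimethylphenyl on a double-bonded ring carbon, next to the ring atom that bears the 4-(methylsulfanyl)phenyl group: 4-fluorophenyl in place of 3,4-dimethylphenyl on a double-bonded ring carbon.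

Within the data shown here, the only measured step is a 2.0-fold lower number from compound 1 to compound 2 (0.30 log units; within the scatter). It concerns a group on a carbonyl carbon, so it gives no direct size for this change. Among the measured compounds shown here, no measured step alters the aryl group on the double-bonded ring carbon, and the expectation therefore remains loose.

Compound 3 at 300 nM is the lowest value in the set, so a modest move to a higher number in this assay is expected rather than a further drop. The expected change is a 2.0-fold higher number from compound 3 to compound 4 (0.30 log units; within the scatter). In this assay the estimate for compound 4 is 600 nM, with an expected range of 120 nM to 3000 nM.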

Compound 4, concentration for 50% growth inhibition: 30000 nM
For compound 4 the middle estimate is 50-fold (1.70 log units) below the measured one; measured number above the stated range.
By their numbers in this assay, from the lowest: compound 3; then compounds 2, 1 and 4 (each within the scatter of the next, the first and the last beyond it).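

In this assay, the aryl group on the double-bonded ring carbon is the one place in the series where a single change is seen to move the number beyond the scatter: a 100-fold higher number from compound 3 to compound 4 (2.00 log units; beyond the scatter), a large step, with 4-fluorophenyl in place of 3,4-dimethylphenyl. Within the data shown here, the only other single-place step, a 2.0-fold lower number from compound 1 to compound 2 (0.30 log units; within the scatter), concerns a group on a carbonyl carbon and stays within the scatter, so the read-out responds far more strongly to this aryl exchange than to that change. The shared core and the 4-(methylsulfanyl)phenyl group stay the same across the pair, which places the whole step on this one group, but no measurement on hand explains its size.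

The exchange removes the methyl groups of 3,4-dimethylphenyl and brings in fluorine in a single step, so the compounds shown cannot separate the loss of the methyl groups from the gain of fluorine. As far as these compounds go, whether an unsubstituted phenyl, 4-methylphenyl or 3-methylphenyl group at this position would give a number nearer that of compound 3 or that of compound 4 remains open.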